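From methoxy to 4-fluorophenoxy on the shared core

The source may report more compounds than this note shows. Statements on the series, on what has been measured and on what is new or still open speak of the compounds shown alone.

In a functional assay on A549 cells (Homo sapiens) for inhibition, read by sulforhodamine B assay, with a stated time of 48 h, tested at 50 uM (a higher number here means more inhibition of growth at the concentration tested, a lower number less inhibition of growth), compound 3 `COc1ccc([C@@H]2CC(=O)c3cc(CC=C(C)C)c(OC)cc3O2)cc1` gives 45%. That number lies within the scatter of the other two measured compounds: compound 1 `CCCOc1ccc([C@@H]2CC(=O)c3cc(CC=C(C)C)c(OC)cc3O2)cc1` gives 43%, and compound 2 `COc1ccc([C@@H]2C/C(=N/OCc3cn(-c4ccc(O)cc4)nn3)c3cc(CC=C(C)C)c(OC)cc3O2)cc1` gives 52%. The three compounds therefore do not separate on these numbers.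

Compound 4 `COc1cc2c(cc1CC=C(C)C)C(=O)C[C@@H](c1ccc(Oc3ccc(F)cc3)cc1)O2` differs from compound 3 at one place: 4-fluorophenyl in place of methyl on an oxygen on an aromatic ring. This puts 4-fluorophenyl in place of methyl on an oxygen on an aromatic ring. Among the measured compounds shown here, the only measured step at that oxygen, hydrogen in place of ethyl on the chain, is a number 2 percentage points higher from compound 1 to compound 3 (within the scatter). For the measured compounds named here, no measured compound carries a ring on that oxygen, so this step is only a weak guide to the new change, and the uncertainty is wide.

With nothing else to go on, the expected outcome in this assay is a number 3 percentage points higher from compound 3 to compound 4 (within the scatter), with no shift beyond the scatter in either direction. For compound 4 the estimated value is 48%, with an expected range of 32% to 66%.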

Compound 4, percent growth inhibition at one concentration: 27%
Compound 4: the middle estimate sits 21 percentage points above what was measured, outside the stated range (below it).
By their numbers in this assay, from the lowest: compound 4; then compounds 1, 3 and 2 (each within the scatter of the next).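

Among the compounds shown here, until this result, the only change measured at this oxygen, a number 2 percentage points higher from compound 1 to compound 3 (within the scatter) in this assay, stayed within the scatter. With 4-fluorophenyl on the oxygen, the shared core gives a number 18 percentage points lower from compound 3 to compound 4 (beyond the scatter) and, against propyl at the same place, a number 16 percentage points lower from compound 1 to compound 4 (beyond the scatter) in this assay, so this position does respond to what it carries, and here the ring goes with less inhibition of growth than either methyl or propyl. Nothing available gives a reason for this fall.

The compounds shown do not separate the ring from its fluorine, so a plain phenyl or a benzyl on the oxygen remains an open case. Also open, from the compounds shown here alone, is whether 4-fluorophenyl would lower the number in the same way on the core of compound 2, which carries the triazole-bearing oxime.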